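The source may hold more compounds than are shown below. What is called first, only, known or untested is meant among the compounds shown, and "the series" means these compounds.

In an ADME assay on L929 cells (Mus musculus) for cytotoxicity, read by resazurin assay, with a stated time of 72 h (on this read-out higher numbers stand for weaker inhibition and lower numbers for stronger inhibition), compound 1 `COCOc1cccc(C(=O)/C=C/c2ccc3c(c2)B(O)OC3)c1` reports only a limit, > 10 ug/mL. Among the compounds with values here, compound 2 `O=C(/C=C/c1ccc2c(c1)B(O)OC2)c1cccc(O)c1` gives 7.56 ug/mL, the only actual number so far. Compound 3 `Nc1cccc(C(=O)/C=C/c2ccc3c(c2)B(O)OC3)c1` differs from compound 2 by amino in place of hydroxy on an aromatic carbon. Within the data shown here, the single measured step, an at least 1.3-fold lower number from compound 1 to compound 2 (0.12 log units; that floor lies within the scatter), changes the same oxygen but never involves amino, so it offers only weak guidance. No shift beyond the scatter is therefore expected. The expected step is a 1.3-fold lower number from compound 2 to compound 3 (0.10 log units; within the scatter). For compound 3 the estimated value is 6 ug/mL, within an expected range of 2 ug/mL to 15 ug/mL.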

Compound 3, half-maximal inhibitory concentration: 10 ug/mL
The estimate for compound 3 lay 1.7-fold (0.22 log units) below the measured number; low and high end bracket the measured number.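

Going from 3-hydroxyphenyl to 3-aminophenyl gives a 1.3-fold higher number from compound 2 to compound 3 (0.12 log units; within the scatter) in this assay, so the read-out does not separate the two groups at this position. The earlier compounds shown here carried only oxygen here, and nitrogen on this carbon now also shows no shift beyond the scatter. The other new step is a number no higher from compound 1 to compound 3 (the limit leaves the size open), and it cannot be read in size, because the starting value is only a limit: the limit of > 10 ug/mL in this assay, at which 1 of the 3 values shown sits.

From the compounds shown here alone, whether a carboxylic acid or a longer chain on this carbon would move the number beyond the scatter stays open. So does whether amino would behave alike elsewhere on the ring.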